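The compounds below may be only part of what the source reports. "The series", "measured", "known", "first", "only" and "open" are said of these compounds alone.

Three compounds of one series were tested in an ADME assay on NIH3T3 cells (Mus musculus) for cytotoxicity, read by MTT assay, with a stated time of 24 h; on this read-out higher numbers stand for weaker inhibition and lower numbers for stronger inhibition. Compound 1 `O=C(CN1CCN(c2ccc([N+](=O)[O-])cc2)CC1)N1CCN(c2nnc(-c3ccccc3)c(-c3ccccc3)n2)CC1` gives only a limit in this assay, > 886000 nM. Compound 2 `Cc1ccc(-c2nnc(N3CCN(C(=O)CN4CCN(c5ccccc5)CC4)CC3)nc2-c2ccc(C)cc2)cc1` likewise gives only a limit, > 914000 nM. Compound 3 `COc1ccc(-c2nnc(N3CCN(C(=O)CN4CCN(c5ccccc5Cl)CC4)CC3)nc2-c2ccc(OC)cc2)cc1` also gives only a limit, > 814000 nM. For the measured compounds named here, none of the three reaches a number, so compound 3 stands level with the others as far as the limits allow, and no step between them can be sized. Compound 4 `COc1ccc(-c2nnc(N3CCN(C(=O)CN4CCN(c5ccc(OC)cc5)CC4)CC3)nc2-c2ccc(OC)cc2)cc1` differs from compound 3 by a single change, 4-methoxyphenyl in place of 2-chlorophenyl on an amine nitrogen in a ring. Going by the values given here, with every value so far a limit, the expected step is a step that the limit leaves unreadable from compound 3 to compound 4, nothing beyond the scatter. For compound 4 the estimated value is 900000 nM, within a range from 400000 nM to 2000000 nM, most likely again reported as a limit.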

Compound 4, half-maximal inhibitory concentration: > 821000 nM
Compound 4 ended at the assay's limit; the forecaster's own chance of this, stated with the estimate: 85%; the middle value is on the limit's open side.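

For the compounds shown here, compound 3 and compound 4 both give only limits in this assay, and no step between them can be read. The compounds shown leave open whether 4-methoxyphenyl in place of 2-chlorophenyl alters the read-out at all.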